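The compounds below may be only part of what the source reports. "The series", "measured", "known", "first", "only" and "open" are said of these compounds alone.

Working notes on the series.

Compound 1 `CSc1nc(-c2ccc(C)cc2)nc2ccc(Cl)cc12` gives 8.64 ug/mL in a functional assay on MCF7 cells (Homo sapiens) for antiproliferative activity, read by MTT assay, with a stated time of 48 h; on this read-out higher numbers stand for weaker inhibition and lower numbers for stronger inhibition. Within the data shown here, compound 2 `Cc1ccc(-c2nc(SCC#N)c3cc(Cl)ccc3n2)cc1` gives 3.35 ug/mL in this assay, the lowest of the two numbers in hand; the only neighbour is compound 1. Among the measured compounds shown here, the single step in hand, a 2.6-fold lower number from compound 1 to compound 2 (0.41 log units; beyond the scatter), describes the cyano group entering on a saturated chain carbon bound to a sulfur.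

Compound 3 `C=CCSc1nc(-c2ccc(C)cc2)nc2ccc(Cl)cc12` is not yet measured. It differs from compound 2 by vinyl in place of cyano on a saturated chain carbon bound to a sulfur. For the measured compounds named here, no measured step covers a cyano giving way to a vinyl; the step from compound 1 to compound 2 is the only one that bears on it, since it shows what the cyano itself is worth, and compound 3 keeps neither the cyano of compound 2 nor the bare hydrogen of compound 1. The number for compound 3 is therefore expected to sit between those of compound 2 and compound 1, with a 1.6-fold higher number from compound 2 to compound 3 (0.22 log units; within the scatter) estimated in this assay. The estimate for compound 3 is 5.5 ug/mL, expected within 2.8 ug/mL to 11 ug/mL.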

Compound 3, half-maximal inhibitory concentration: 8.03 ug/mL
The estimate for compound 3 lay 1.5-fold (0.16 log units) below the measured number, and the stated range covers the measured number.
By their numbers in this assay, from the lowest: compound 2; then compounds 3 and 1 (each within the scatter of the next).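

On a saturated chain carbon bound to a sulfur, the vinyl does not reproduce what the cyano gives in this assay: the change shows a 2.4-fold higher number from compound 2 to compound 3 (0.38 log units; beyond the scatter), although both groups count 2 heavy atoms. Against the bare hydrogen, the vinyl shows a 1.1-fold lower number from compound 1 to compound 3 (0.03 log units; within the scatter), so among these three compounds only the cyano stands apart, and adding 2 heavy atoms at this place is not enough to give the lower number of compound 2. No measurement in hand bears on why the cyano differs from the vinyl here.

As far as these compounds go, whether a longer chain ending in a nitrile, a carboxylic acid or an amide at this place would match the cyano stays open. Also open, from the compounds shown here alone, is whether the cyano step would hold if the 4-methylphenyl-bearing shared core were changed.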